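Prenyl Ether at the Ring Oxygen: An Expected Value

This account rests on a few compounds, and the source may have more. Where it says the series, first, only, none or still open, it means among the compounds named here.

Of the compounds shown here, three sharing one core have been tested in a functional assay on PANC-1 cells (Homo sapiens) for inhibition, read by MTT assay, with a stated time of 24 h, tested at 10 uM; a lower number here means less inhibition, a higher number more inhibition at the concentration tested (going by the name of the read-out). Compound 1 `CC(C)=CCC1Cc2c(O)cc(=O)n(CCCO)c2CC1(C)C` gives 25.6%. Compound 2 `CC(C)=CCC/C(C)=C/CC1Cc2c(O)cc(=O)n(CCCO)c2CC1(C)C` gives 28.7%. Compound 3 `CC(C)=CCC1Cc2c(OC(=O)Nc3ccc(Cl)cc3)cc(=O)n(CCCO)c2CC1(C)C` gives 49.8%. Compound 2 stands second highest of the three; its number is within the scatter of compound 1, and compound 3 lies beyond the scatter above it. The step of a number 3.1 percentage points higher from compound 1 to compound 2 (within the scatter) adds a chain away from the oxygen and stays within the scatter. The step of a number 24.2 percentage points higher from compound 1 to compound 3 (beyond the scatter) changes the hydrogen on the oxygen on the aromatic ring and gives a modest rise beyond the scatter.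

Compound 4 `CC(C)=CCC/C(C)=C/CC1Cc2c(OCC=C(C)C)cc(=O)n(CCCO)c2CC1(C)C` differs from compound 2 as follows: 3-methylbut-2-en-1-yl in place of hydrogen on an oxygen on an aromatic ring. This change sits at the same oxygen as the step from compound 1 to compound 3, but the entering group is a chain rather than a carbamoyl group, so that step is only a loose guide. A small rise is expected, as in a number 9.3 percentage points higher from compound 2 to compound 4 (within the scatter), yet it may well remain within the scatter. Compound 4 is therefore estimated to give 38% in this assay, with a range from 22% to 56%.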

Compound 4, a percentage reported as inhibition, at one concentration (the size of the read-out at that concentration, not a potency): 30.3%
Beside the measured number, compound 4's estimate is 7.7 percentage points above it; measured number inside the range.
By their numbers in this assay, from the lowest: compounds 1, 2 and 4 (each within the scatter of the next); then compound 3.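

In this assay, putting 3-methylbut-2-en-1-yl on the oxygen on the aromatic ring gives a number 1.6 percentage points higher from compound 2 to compound 4 (within the scatter) and so shows no clear effect. Among the compounds shown here, until now, the only change at this oxygen was the (4-chlorophenyl)carbamoyl group, with a number 24.2 percentage points higher from compound 1 to compound 3 (beyond the scatter) as its step, so replacing the hydrogen there is not enough on its own to give a rise beyond the scatter, although the two steps start from compounds with different chains. No measurement here explains why the two entering groups behave differently.

As far as these compounds go, it remains open whether the (4-chlorophenyl)carbamoyl group would give a similar rise on compound 2. Nor do these compounds show what a methyl group, an acetyl group or a chain ending in an amine would do at this oxygen.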